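This account rests on a few compounds, and the source may have more. Where it says the series, first, only, none or still open, it means among the compounds named here.

In a functional assay on HCT-116 cells (Homo sapiens) for inhibition, read by sulforhodamine B assay, with a stated time of 48 h, tested at 50 uM (a higher number here means more inhibition of growth at the concentration tested, a lower number less inhibition of growth), compound 1 `COc1ccc([C@@H]2C/C(=N/OCc3cn(-c4ccc(O)cc4)nn3)c3cc(CC=C(C)C)c(OC)cc3O2)cc1` gives 65% while compound 2 `COc1ccc([C@@H]2C/C(=N/OCc3cn(-c4cccc(CO)c4)nn3)c3cc(CC=C(C)C)c(OC)cc3O2)cc1` gives 27% and compound 3 `COc1ccc([C@@H]2C/C(=N/OCc3cn(-c4ccccc4CO)nn3)c3cc(CC=C(C)C)c(OC)cc3O2)cc1` gives 100% as the highest of the three. Compound 4 `COc1ccc([C@@H]2C/C(=N/OCc3cn(-c4cccnc4Cl)nn3)c3cc(CC=C(C)C)c(OC)cc3O2)cc1` differs from compound 3 by 2-chloropyridin-3-yl in place of 2-(hydroxymethyl)phenyl on an aromatic nitrogen with 2-chloropyridin-3-yl in place of 2-(hydroxymethyl)phenyl on an aromatic nitrogen. The measured steps at this same place are a number 38 percentage points lower from compound 1 to compound 2 (beyond the scatter) and a number 35 percentage points higher from compound 1 to compound 3 (beyond the scatter) and a number 73 percentage points higher from compound 2 to compound 3 (beyond the scatter) and all are large. Among the compounds with values here, no measured compound carries 2-chloropyridin-3-yl, so the size remains uncertain. Both other measured groups give lower numbers than compound 3 does at 100% in this series. A large fall is expected as a number 40 percentage points lower from compound 3 to compound 4 (beyond the scatter) in this assay on this basis. Compound 4 is estimated at 60% with an expected range of 25% to 100% here.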

Compound 4, percent growth inhibition at one concentration: 47%
Compound 4: middle estimate off by 13 percentage points, on the high side; low and high end bracket the measured number.
By their numbers in this assay, from the lowest: compound 2; then compound 4; then compound 1; then compound 3.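

In this assay, 2-chloropyridin-3-yl in place of 2-(hydroxymethyl)phenyl gives a number 53 percentage points lower from compound 3 to compound 4 (beyond the scatter) as the step, so the top value of compound 3 does not carry over to this group on the aromatic nitrogen. The new group still falls inside the range of the earlier groups, with a number 20 percentage points higher from compound 2 to compound 4 (beyond the scatter) on one side and a number 18 percentage points lower from compound 1 to compound 4 (beyond the scatter) on the other, so a ring without hydroxymethyl keeps part of the growth inhibition. No measurement at hand explains these differences.

The change swaps the ring and its substituent together, and a 2-chlorophenyl group would separate the two. From the compounds shown here alone, whether the hydroxymethyl itself matters remains open, which a 2-(aminomethyl)phenyl or 2-carboxyphenyl group at this place would test.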